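Swapping ethynyl for 3-fluorophenyl

The source may hold more compounds than are shown below. What is called first, only, known or untested is meant among the compounds shown, and "the series" means these compounds.

In a functional assay on HCT-116 cells (Homo sapiens) for antiproliferative activity, read by MTT assay, with a stated time of 72 h (a lower number here means a stronger inhibitor, a higher number a weaker inhibitor), compound 1 (`O=C(CCc1cccc2c1B(O)OC2)Nc1cccc(Br)c1`) gives 1400 nM and compound 2 (`C#Cc1cccc(NC(=O)CCc2cccc3c2B(O)OC3)c1`) gives 3600 nM as the higher of the two numbers, which makes compound 2 the weaker inhibitor of this pair. Compound 3 (`O=C(CCc1cccc2c1B(O)OC2)Nc1cccc(-c2cccc(F)c2)c1`) has 3-fluorophenyl in place of ethynyl on an aromatic carbon, a change counted as 3-fluorophenyl in place of ethynyl on an aromatic carbon in full. Going by the values given here, only one measured step bears on this: a 2.6-fold higher number from compound 1 to compound 2 (0.41 log units; beyond the scatter) when ethynyl replaces bromo at that same place. Among the compounds with values here, that step is modest and beyond the scatter, but it says little about a group that brings a whole ring, and no measured compound carries one there. A step of similar modest size at most is therefore expected, with no firm direction. The estimated change is a 1.4-fold lower number from compound 2 to compound 3 (0.16 log units; within the scatter) in this assay as a cautious guess. For compound 3 the expected value is 2500 nM (estimated range 600 nM to 10000 nM).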

Compound 3, half-maximal inhibitory concentration: 460 nM
Compound 3: the middle estimate sits 5.4-fold (0.74 log units) above what was measured; measured number outside the range, below it.
By their numbers in this assay, from the lowest: compound 3; then compound 1; then compound 2.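

In this assay, this position accepts far more than the bromo and ethynyl groups seen so far: 3-fluorophenyl, with its one six-membered aromatic ring and 7 heavy atoms, gives a 7.8-fold lower number from compound 2 to compound 3 (0.89 log units; beyond the scatter), and against bromo it gives a 3.0-fold lower number from compound 1 to compound 3 (0.48 log units; beyond the scatter). Both steps lie beyond the scatter, so adding a whole ring here does not cost activity in these compounds, and compound 3 has the lowest number of the three. No measurement available here explains this gain.

The compounds shown leave open how much of the gain comes from the ring and how much from its fluorine, which a plain phenyl group would help to separate. Going by these compounds, whether a ring carrying an amine or a carboxylic acid at this position would do as well also remains open.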